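The source may report more compounds than this note shows. Statements on the series, on what has been measured and on what is new or still open speak of the compounds shown alone.

Measured so far:
compound 1, `O=C(O)CC/C=C\CC1COC(c2ccccc2Cl)OC1c1cccnc1`: 48 nM
compound 2, `O=C(O)CC/C=C\CC1COC(c2ccsc2)OC1c1cccnc1`: 500 nM

In an assay for inhibition of Thromboxane-A synthase (Homo sapiens), using microsomes (a lower number here means a stronger inhibitor, a higher number a weaker inhibitor), compound 2 gives 500 nM, the higher of the two numbers recorded. Within the data shown here, the nearest neighbour is compound 1, and the only measured step, a 10-fold higher number from compound 1 to compound 2 (1.02 log units; beyond the scatter), is what separates them: an aromatic group on the saturated ring carbon was exchanged, and the number rose well beyond the scatter.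

The next compound, compound 3 `O=C(O)CC/C=C\CC1COC(c2cccs2)OC1c1cccnc1`, differs from compound 2 by thiophen-2-yl in place of thiophen-3-yl on a saturated ring carbon. This is an exchange of one thiophene attachment for the other on the same saturated carbon of the shared core, the two having the same atoms joined differently.

Among the measured compounds shown here, no measured step concerns this exchange. For the measured compounds named here, the one step available, a 10-fold higher number from compound 1 to compound 2 (1.02 log units; beyond the scatter), replaced a 2-chlorophenyl group by a thiophene and so does not tell how the two thiophene attachments compare with each other; it only shows that the group at this position matters. Without a direct precedent, no step beyond the scatter is expected from compound 2 to compound 3, and the step is estimated at a 1.4-fold lower number from compound 2 to compound 3 (0.15 log units; within the scatter). For compound 3 the estimate in this assay is 350 nM, with a range of 120 nM to 1000 nM.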

Compound 3, half-maximal inhibitory concentration: 71 nM
Estimate against measurement, compound 3: 4.9-fold (0.69 log units) above; the measured number lies below the stated range.
By their numbers in this assay, from the lowest: compounds 1 and 3 (each within the scatter of the next); then compound 2.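

In this assay, the way the thiophene is joined to the saturated ring carbon between the two ring oxygen atoms matters on its own: with the same atoms joined differently, the change gives a 7.0-fold lower number from compound 2 to compound 3 (0.85 log units; beyond the scatter) and lies beyond the scatter. The earlier step could be read as a loss on leaving 2-chlorophenyl for any thiophene, but the new result rules that reading out, as thiophen-2-yl in place of 2-chlorophenyl gives only a 1.5-fold higher number from compound 1 to compound 3 (0.17 log units; within the scatter) and these two groups cannot be told apart here, leaving thiophen-3-yl as the group that goes with the higher number among these three compounds. No measurement at hand accounts for the difference between the two thiophene attachments.

As far as these compounds go, it remains open whether an unsubstituted phenyl or a furan-2-yl group on this carbon would give a number in line with compound 1 and compound 3 or with compound 2, and whether a chlorine atom on the thiophen-2-yl group would move the number at all. Also open, from the compounds shown here alone, is whether the gap between the two thiophene attachments persists when the pyridin-3-yl group or the 5-carboxypent-2-en-1-yl group of the shared core is replaced, for instance by a longer chain ending in a carboxylic acid.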